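Adding a Second Hydroxy to the Hydrazone Phenyl

This account rests on a few compounds, and the source may have more. Where it says the series, first, only, none or still open, it means among the compounds named here.

Going by the values given here, compound 2 `Cc1c(C(=O)N/N=C\c2ccc(O)cc2)oc2cccc(O)c12` is the only compound here with a definite number: in a functional assay on PC-3 cells (Homo sapiens) for inhibition (on this read-out lower numbers stand for stronger inhibition and higher numbers for weaker inhibition), compound 2 gives 21700 nM. Compound 1 `Cc1c(C(=O)N/N=C\c2ccccc2F)oc2cccc(O)c12` reaches only a limit of this assay, >= 40000 nM, which is the limit of >= 40000 nM in this assay, at which 1 of the 2 values shown sits. Among the compounds with values here, the single measured step, an at least 1.8-fold lower number from compound 1 to compound 2 (0.26 log units; that floor lies within the scatter), is the sole guide, and it brought in a hydroxy group with a lower number of uncertain size. Compound 3 `Cc1c(C(=O)N/N=C\c2ccc(O)cc2O)oc2cccc(O)c12` carries hydroxy in place of hydrogen on an aromatic carbon. For compound 3 a step of a 1.4-fold lower number from compound 2 to compound 3 (0.16 log units; within the scatter) is expected, small and uncertain in direction. Compound 3 is therefore estimated at 15000 nM, within 5000 nM to 40000 nM.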

Compound 3, half-maximal inhibitory concentration: 14800 nM
Compound 3: middle estimate off by 1.0-fold (0.01 log units), on the high side; measured number inside the range.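

Placing a hydroxy on this aromatic carbon, ortho to a large group, gives a 1.5-fold lower number from compound 2 to compound 3 (0.17 log units; within the scatter), so the 4-hydroxyphenyl and 2,4-dihydroxyphenyl groups cannot be told apart here. Going by these compounds alone, replacing 2-fluorophenyl with 2,4-dihydroxyphenyl gives an at least 2.7-fold lower number from compound 1 to compound 3 (0.43 log units; beyond the scatter), the first step here to clear the scatter. Its true size remains unknown, as compound 1 reaches only a limit: the limit of >= 40000 nM in this assay, at which 1 of the 3 values shown sits.

As far as these compounds go, whether a 2-hydroxyphenyl group alone would match compound 3 remains open. So does the outcome with a methoxy group or an amine at this place.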